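A few compounds are considered here, and "the series" means these few. Any claim that something is new, unique, unknown or untested is made for them only; others in the source may bear on it.

In an assay on cells for inhibition of Ectonucleotide pyrophosphatase/phosphodiesterase family member 1 (Homo sapiens), with a stated time of 60 min (on this read-out lower numbers stand for stronger inhibition and higher numbers for weaker inhibition), compound 1 `COc1cc2nc(/C=C/c3ccccn3)nc(N3CCC(CCNS(N)(=O)=O)CC3)c2cc1OC` gives 71 nM, the second highest of the three numbers recorded. Compound 2 `COc1cc2nc(/C=C/c3cccnc3)nc(N3CCC(CCNS(N)(=O)=O)CC3)c2cc1OC` gives 58 nM, and the step of a 1.2-fold lower number from compound 1 to compound 2 (0.09 log units; within the scatter) stays within the scatter. Compound 3 `COc1cc2nc(/C=C/c3cccc(F)c3)nc(N3CCC(CCNS(N)(=O)=O)CC3)c2cc1OC` gives 3580 nM, reached by the large step of a 50-fold higher number from compound 1 to compound 3 (1.70 log units; beyond the scatter) and equally by a 62-fold higher number from compound 2 to compound 3 (1.79 log units; beyond the scatter). Compound 4 `COc1cc2nc(/C=C/c3ccc(F)cc3)nc(N3CCC(CCNS(N)(=O)=O)CC3)c2cc1OC` differs from compound 1 as follows: 4-fluorophenyl in place of pyridin-2-yl on a double-bonded chain carbon bound to a double-bonded chain carbon. The two large steps, which each put 3-fluorophenyl in place of pyridin-2-yl or pyridin-3-yl, bear directly on this change, so a large upward step is expected in this assay, namely a 42-fold higher number from compound 1 to compound 4 (1.63 log units; beyond the scatter). Compound 4 is therefore estimated at 3000 nM, with an expected range from 800 nM to 12000 nM.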

Compound 4, inhibition constant: 465 nM
Compound 4: middle estimate off by 6.5-fold (0.81 log units), on the high side; measured number below the stated range.
By their numbers in this assay, from the lowest: compounds 2 and 1 (each within the scatter of the next); then compound 4; then compound 3.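

In this assay, 4-fluorophenyl in place of 3-fluorophenyl on a double-bonded chain carbon gives a 7.7-fold lower number from compound 3 to compound 4 (0.89 log units; beyond the scatter), so this position distinguishes between the two fluorophenyl groups. A carbon-only ring here therefore need not carry the full loss seen with compound 3, yet the pyridyl compounds still give the lower numbers, with a 6.5-fold higher number from compound 1 to compound 4 (0.82 log units; beyond the scatter) and an 8.0-fold higher number from compound 2 to compound 4 (0.90 log units; beyond the scatter) as the remaining gaps. Nothing available explains these differences. The compounds shown leave open how an unsubstituted phenyl group or a pyridine ring bearing an amine would read at this position.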